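Taking the acetyl off compound 2

The source may hold more compounds than are shown below. What is called first, only, known or untested is meant among the compounds shown, and "the series" means these compounds.

Among the compounds with values here, in an ADME assay (liver) for metabolic stability, with Liver microsome (Homo sapiens) as the target, read by LC-MS, using microsomes, tested at 1 uM (a higher number here means that the compound lasts longer, a lower number that the compound disappears faster), compound 2 (`CNc1nc(NCCCN(C)C)c2sc(-c3ccc(C(C)=O)cc3)cc2n1`) gives 0.35 h, the lower of the two numbers measured so far, while compound 1 (`CNc1nc(NCCCN(C)C)c2sc(-c3ccc(C(F)(F)F)cc3)cc2n1`) gives 2.07 h. Compound 3 (`CNc1nc(NCCCN(C)C)c2sc(-c3ccccc3)cc2n1`) has hydrogen in place of acetyl on an aromatic carbon. Within the data shown here, only one measured step bears on this position: a 5.9-fold lower number from compound 1 to compound 2 (0.77 log units; beyond the scatter), which is beyond the scatter. That step does not include a compound with hydrogen here, so it offers only a rough guide. A rise is expected, and the expected step is a 2.6-fold higher number from compound 2 to compound 3 (0.41 log units; beyond the scatter). For compound 3 the estimated half-life is 0.9 h, within a range of 0.35 h to 2.2 h.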

Compound 3, half-life: 5.75 h
Compound 3: middle estimate off by 6.4-fold (0.81 log units), on the low side, and the stated range ends below it.
By their numbers in this assay, from the lowest: compound 2; then compound 1; then compound 3.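

In this assay, hydrogen at this place gives the highest number of the three, and both substituents fall short of it: a 16-fold higher number from compound 2 to compound 3 (1.22 log units; beyond the scatter) and a 2.8-fold higher number from compound 1 to compound 3 (0.44 log units; beyond the scatter). Removing the acetyl gives the larger step, whereas the earlier pair ranked only acetyl against trifluoromethyl, leaving hydrogen unplaced. Nothing at hand gives a reason for these steps. 

Open, from the compounds shown here alone, is whether any group at this place, such as fluorine, a nitrile or an amine, can match hydrogen. Also open, going by these compounds, is whether the same order holds with changes elsewhere on the shared core.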